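Carboxy Side Chain Gives Way to (4-Fluorobenzyl)oxy

A few compounds are considered here, and "the series" means these few. Any claim that something is new, unique, unknown or untested is made for them only; others in the source may bear on it.

In an ADME assay on L02 cells (Homo sapiens) for cytotoxicity, read by MTT assay, with a stated time of 48 h (on this read-out lower numbers stand for stronger inhibition and higher numbers for weaker inhibition), compound 3 `CCn1c(C(=O)N(C)CC(=O)O)ccc1C(CC)(CC)c1ccc(OCC(O)C(C)(C)C)c(C)c1` gives 32600 nM as the highest number of the three measured, with compound 1 `CCn1c(C(=O)N(C)CCC#N)ccc1C(CC)(CC)c1ccc(OCC(O)C(C)(C)C)c(C)c1` at 14900 nM and compound 2 `C=CCN(C)C(=O)c1ccc(C(CC)(CC)c2ccc(OCC(O)C(C)(C)C)c(C)c2)n1CC` at 6300 nM on the lower side. Compound 4 `CCn1c(C(=O)OCc2ccc(F)cc2)ccc1C(CC)(CC)c1ccc(OCC(O)C(C)(C)C)c(C)c1` has not yet been measured. Relative to compound 3, it carries (4-fluorobenzyl)oxy in place of (carboxymethyl)(methyl)amino on a carbonyl carbon. Two modest measured steps bear on this change: a 2.2-fold higher number from compound 1 to compound 3 (0.34 log units; beyond the scatter) on replacing cyanomethyl with carboxy and a 5.2-fold higher number from compound 2 to compound 3 (0.71 log units; beyond the scatter) on replacing vinyl with carboxy. Both measured compounds without the carboxy group therefore sit lower than compound 3, and none of the three goes against this. Among the measured compounds shown here, no measured compound carries the (4-fluorobenzyl)oxy group, so these steps are only an indirect guide to size. A modest fall is expected, with a 3.6-fold lower number from compound 3 to compound 4 (0.56 log units; beyond the scatter) as the estimated step in this assay for this change. Compound 4 is estimated at 9000 nM with a range of 3000 nM to 27000 nM expected for the measurement.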

Compound 4, half-maximal inhibitory concentration: 14900 nM
The estimate for compound 4 lay 1.7-fold (0.22 log units) below the measured number; low and high end bracket the measured number.
By their numbers in this assay, from the lowest: compound 2; then compounds 1 and 4 (each within the scatter of the next); then compound 3.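

In this assay, placing (4-fluorobenzyl)oxy on the carbonyl carbon gives a 2.2-fold lower number from compound 3 to compound 4 (0.34 log units; beyond the scatter), so a group with neither the carboxy unit nor the amide nitrogen also sits lower than compound 3, as the two amides without the carboxy unit do. Against those two amides the result divides, with no change at the digits printed from compound 1 to compound 4 (within the scatter) for (2-cyanoethyl)(methyl)amino but a 2.4-fold higher number from compound 2 to compound 4 (0.37 log units; beyond the scatter) for allyl(methyl)amino, so the aromatic ring entering here does not bring the number down to that of compound 2. Nothing given here accounts for these differences.

From the compounds shown here alone, how a plain benzyloxy group without the fluorine, or a small methoxy group, would compare on the same carbonyl carbon stays open. So does whether the step from compound 3 follows the aromatic ring or the loss of the amide nitrogen, which a benzylamino group on that carbon would help to separate.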